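Piperidine Replaces Methylpiperazine on the Carbonyl Carbon

A few compounds are considered here, and "the series" means these few. Any claim that something is new, unique, unknown or untested is made for them only; others in the source may bear on it.

Of the compounds shown here, three built on one shared core have been tested in a functional assay on NIH3T3 cells (Mus musculus) for inhibition, read by neutral red uptake, with a stated time of 24 h; on this read-out lower numbers stand for an effect already at smaller amounts and higher numbers for an effect only at larger amounts of compound. Compound 1 `CCN(CC)CCCC(C)NC(=O)OC1=C(c2cccc3ncccc23)Oc2cc3ccccc3cc2-n2cccc21` gives 6000 nM, compound 2 `CN1CCN(C(=O)OC2=C(c3cccc4ncccc34)Oc3cc4ccccc4cc3-n3cccc32)CC1` gives 450 nM, and compound 3 `CC(=O)OC1=C(c2cccc3ccccc23)Oc2cc3c(cc2-n2cccc21)OCCO3` gives 100 nM. Among these three numbers compound 2 stands second highest: compound 3 is the nearest with a lower number, and compound 1 is the furthest with a higher one. Compound 1 and compound 2 differ only in the group attached to the carbonyl carbon. That one change gave a 13-fold lower number from compound 1 to compound 2 (1.12 log units; beyond the scatter), a large step well beyond the scatter.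

Compound 4 `O=C(OC1=C(c2cccc3ncccc23)Oc2cc3ccccc3cc2-n2cccc21)C1CCNCC1` has not yet been measured. It differs from compound 2 in a single place: piperidin-4-yl in place of 4-methylpiperazin-1-yl on a carbonyl carbon. Among the measured compounds shown here, the only measured step that bears on this is the one from compound 1 to compound 2, where exchanging the group on the same carbonyl carbon shifted the number strongly, so this position is clearly sensitive. Whether the incoming group pushes the number down or up cannot be read from the data in hand. The expected step is therefore taken as a 1.1-fold lower number from compound 2 to compound 4 (0.05 log units; within the scatter), small and close to the scatter, with a wide range around it. Compound 4 is estimated at 400 nM, expected to fall between 120 nM and 1500 nM.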

Compound 4, half-maximal effective concentration in the NIH3T3 assay: 600 nM
The estimate for compound 4 lay 1.5-fold (0.18 log units) below the measured number; low and high end bracket the measured number.
By their numbers in the NIH3T3 assay, from the lowest: compound 3; then compounds 2 and 4 (each within the scatter of the next); then compound 1.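

In the NIH3T3 assay the two rings on the carbonyl carbon cannot be told apart (a 1.3-fold higher number from compound 2 to compound 4 (0.12 log units; within the scatter)), so this position accepts piperidin-4-yl as well as 4-methylpiperazin-1-yl, even though the rings differ in their ring atoms and only piperidin-4-yl carries a hydrogen-bond donor. The other comparison (a 10-fold lower number from compound 1 to compound 4 (1.00 log units; beyond the scatter)) shows that the large gap from the open chain of compound 1 is not tied to one ring, since both ring compounds lie well below it. In a physicochemical assay for solubility, read by HPLC, with a stated time of 24 h, at pH 3 (a higher number here means a more soluble compound, a lower number a less soluble compound), compound 2 gives 204000 nM and compound 4 gives 271000 nM, a pair again within the scatter (a 1.3-fold higher number from compound 2 to compound 4 (0.12 log units; within the scatter)), and nothing at hand gives a reason for any of these results.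

From the compounds shown here alone, what remains open is whether the ring nitrogen matters at all, which a cyclohexyl ring on the same carbonyl carbon would test. Also open, going by these compounds, is how far a ring can be reshaped here, for instance to a morpholine or a smaller azetidine, before the number in the NIH3T3 assay shifts beyond the scatter.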